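The source may report more compounds than this note shows. Statements on the series, on what has been measured and on what is new or still open speak of the compounds shown alone.

Series notes. Compound 1 `COc1ccc(OCCCCCN2CCCC(COC(=O)c3ccccc3N3C(=O)CC(C)C3=O)C2)cc1` and compound 2 `COc1ccc(OCCCCCN2CCCC(COC(=O)c3coc4ccccc4c3=O)C2)cc1` share the methoxy-bearing aryl ether chain and differ in the ester; compound 3 `O=C(OCC1CCCN(CCCCCOc2ccc(Cl)cc2)C1)c1ccccc1-c1ccccc1` carries a chloro in its place together with the biphenyl ester. In an in vitro functional assay on HEK ts201 cells for antagonist activity at Neuronal acetylcholine receptor; alpha4/beta2 (Homo sapiens), read by fluorescence and calcium flux (on this read-out higher numbers stand for weaker inhibition and lower numbers for stronger inhibition), compound 1 gives 14500 nM and compound 2 gives 10000 nM. In this assay compound 3 gives 14500 nM, level with compound 1 at the digits printed, and within the scatter of compound 2 as well; none of the three numbers separates from the others beyond the usual repeat scatter.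

Compound 4 `COc1ccc(OCCCCCN2CCCC(COC(=O)c3ccccc3-c3ccccc3)C2)cc1` keeps the biphenyl ester of compound 3 and takes the aryl ether of compound 1 and compound 2. The change from compound 3 is methoxy in place of chloro on an aromatic carbon on an aromatic carbon of a six-membered aromatic ring of carbon only. Going by the values given here, no pair of measured compounds isolates this change, so the step is read from compound 1 and compound 2 carrying methoxy at the same spot at values within the scatter of compound 3.

The step from compound 3 to compound 4 in this assay is expected to be none beyond the scatter, a 1.0-fold lower number from compound 3 to compound 4 (0.02 log units; within the scatter). For compound 4 in this assay the estimate is 14000 nM, within 6000 nM to 35000 nM.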

Compound 4, half-maximal inhibitory concentration: 14500 nM
Estimate against measurement, compound 4: 1.0-fold (0.02 log units) below; the range from low to high includes it.
By their numbers in this assay, from the lowest: compounds 2, 1, 3 and 4 (each within the scatter of the next).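

In this assay, the exchange of chloro for methoxy on an aromatic carbon, para to a large group, can now be read directly: no change at the digits printed from compound 3 to compound 4 (within the scatter), so the two groups are not told apart at this position on the biphenyl ester. With methoxy held fixed, the ester can also be read: phenyl in place of 3-methyl-2,5-dioxopyrrolidin-1-yl on an aromatic carbon gives no change at the digits printed from compound 1 to compound 4 (within the scatter), and the change of the whole ester group gives a 1.5-fold higher number from compound 2 to compound 4 (0.16 log units; within the scatter), so none of the three ester groups separates from the others. Nothing available bears on why these numbers stay together.

From the compounds shown here alone, all four compounds lie within the scatter of one another, so it remains open whether any change to this series moves the number at all. Going by these compounds, whether an amine or a carboxylic acid at this spot, or a longer chain in place of the present one, would separate from these values also stays open.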